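The compounds below may be only part of what the source reports. "The series", "measured", "known", "first", "only" and "open" are said of these compounds alone.

Compound 1 `CC(C)(C)N(NC(=O)c1ccccc1)C(=O)c1ccccc1F` and compound 2 `COc1cccc(C(=O)NN(C(=O)c2cc(C)cc(C)c2)C(C)(C)C)c1` share a diacylhydrazine core. In an assay on cells for agonist activity at ecdysone receptor (Bombyx mori), read by a luciferase reporter, with a stated time of 24 h (a lower number here means that less compound is needed, a higher number that more compound is needed for the effect), compound 1 gives 309 nM, the higher of the two numbers, while compound 2 gives 66.1 nM, a value lower than compound 1 by a margin that lies beyond the usual scatter. Compound 3 `CCCCCCC(=O)N(NC(=O)c1ccccc1)C(C)(C)C` has not yet been measured. It differs from compound 1 in one place: hexyl in place of 2-fluorophenyl on a carbonyl carbon. For the measured compounds named here, no measured pair shows this change, so the size of the step in this assay is not known from the data; a higher number for compound 3 than for compound 1 is expected, by a step of some size beyond the scatter. The step from compound 1 to compound 3 is estimated to be a 4.9-fold higher number from compound 1 to compound 3 (0.69 log units; beyond the scatter). For compound 3 the value in this assay is estimated at 1500 nM, within a range from 400 nM to 6000 nM.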

Compound 3, half-maximal effective concentration: 7240 nM
For compound 3 the middle estimate is 4.8-fold (0.68 log units) below the measured one; the whole stated range lies below it.
By their numbers in this assay, from the lowest: compound 2; then compound 1; then compound 3.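

Within this assay, replacing 2-fluorophenyl with hexyl on a carbonyl carbon gives a 23-fold higher number from compound 1 to compound 3 (1.37 log units; beyond the scatter) and so marks this place as one where the choice of group matters greatly. Compound 1 and compound 2 both carry a six-membered aromatic ring of carbon only on this carbonyl carbon, so neither could show what follows when an open chain takes the place of the ring. Nothing shown here bears on why the step is so large.

This single change removes the ring and the fluorine together, so their shares in the step remain unseparated. The compounds shown leave open whether plain phenyl or cyclohexyl at this place would stay close to compound 1, and how a shorter chain such as butyl would compare with hexyl.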